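The source may report more compounds than this note shows. Statements on the series, on what has been measured and on what is new or still open speak of the compounds shown alone.

Compound 1 `CCCc1cc(N)c2cc(NC(=O)/C=C/c3ccc(Cl)cc3)ccc2n1` is the starting point. For the measured compounds named here, in an assay on isolated protein for displacement of a labelled ligand from melanin-concentrating hormone receptor 1 (Homo sapiens) (a higher number here means a weaker inhibitor, a lower number a stronger inhibitor), compound 1 gives 6 nM, the second highest of the three numbers measured so far. Compound 3 `CCCc1cc(OC)c2cc(NC(=O)/C=C/c3ccc(C(F)(F)F)cc3)ccc2n1` gives 26 nM in this assay, and compound 2 `CCc1cc(N)c2cc(NC(=O)/C=C/c3ccc(C(F)(F)F)cc3)ccc2n1` gives 1.2 nM; both differ from compound 1 in more than one place, so neither isolates a single change. Going by the values given here, compound 4 `CCCc1cc(N)c2cc(NC(=O)/C=C/c3ccc(SC)cc3)ccc2n1` differs from compound 1 in exactly one place: methylsulfanyl in place of chloro on an aromatic carbon No measured pair shows this change on its own. The step of a 1.5-fold higher number from compound 1 to compound 4 (0.18 log units; within the scatter) is expected to be small, likely within the usual scatter, with a slight lean toward a higher number. Compound 4 is therefore estimated at 9 nM, with a range from 3 nM to 30 nM.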

Compound 4, half-maximal inhibitory concentration: 9 nM
Estimate against measurement, compound 4: no gap at the digits printed, and the stated range covers the measured number.
By their numbers in this assay, from the lowest: compound 2; then compounds 1 and 4 (each within the scatter of the next); then compound 3.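

For the compounds shown here, compound 1 and compound 4 form the first pair here that differs in one place only, and in this assay the step of a 1.5-fold higher number from compound 1 to compound 4 (0.18 log units; within the scatter) shows that methylsulfanyl can replace chloro at this position, para to a large group, without a change beyond the scatter. The entering group has 2 heavy atoms and 1 hydrogen-bond acceptor, the leaving group 1 heavy atom and no acceptor. No measurement here explains this result.

From the compounds shown here alone, how an amine, a carboxylic acid or ethylsulfanyl would behave at this position remains open. The effect of trifluoromethyl here is also unresolved: compound 2 and compound 3 carry it, but each differs from compound 1 elsewhere too.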